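The compounds below may be only part of what the source reports. "The series", "measured", "known", "first", "only" and "open" are said of these compounds alone.

- Compound 1 `Cc1cc(=O)c2c(O)c(CN3CCCCC3)c(O)c([C@H]3CCN(C)C[C@H]3O)c2o1` gives 32% in a functional assay on HL-60 cells (Homo sapiens) for inhibition, read by MTT assay, with a stated time of 48 h, tested at 10 uM; a higher number here means more inhibition of growth at the concentration tested, a lower number less inhibition of growth
- Compound 2 `Cc1oc2c([C@H]3CCN(C)C[C@H]3O)c(O)cc(O)c2c(=O)c1C(O)c1ccccc1Br` gives 52% in this assay

Of these two numbers, compound 2 holds the higher one, and its gap to compound 1 lies beyond the usual scatter. Compound 3 `Cc1oc2c([C@H]3CCN(C)C[C@H]3O)c(O)cc(O)c2c(=O)c1C(O)c1cc(F)cc(F)c1` has not been measured yet. It carries 3,5-difluorophenyl in place of 2-bromophenyl on a saturated chain carbon bound to an aromatic carbon and an oxygen on a saturated carbon, and the full count of the change is 3,5-difluorophenyl in place of 2-bromophenyl on a saturated chain carbon bound to an aromatic carbon and an oxygen on a saturated carbon here. For the measured compounds named here, no measured pair of compounds shows this swap, so its direction cannot be read from the data. The best starting point is therefore compound 2 at 52% in this assay, since the rest of the structure stays the same. The estimated step of a number 4 percentage points lower from compound 2 to compound 3 (within the scatter) is expected to stay within the scatter. Compound 3 is expected at 48%, with an estimated range of 30% to 66%.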

Compound 3, percent growth inhibition at one concentration: 30%
Compound 3: the middle estimate sits 18 percentage points above what was measured; low and high end bracket the measured number.
By their numbers in this assay, from the lowest: compounds 3 and 1 (each within the scatter of the next); then compound 2.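

The aryl group on this saturated chain carbon is not a neutral choice in this assay: changing 2-bromophenyl to 3,5-difluorophenyl gives a number 22 percentage points lower from compound 2 to compound 3 (beyond the scatter) on an otherwise unchanged structure. The two groups both contain one six-membered aromatic ring of carbon only and have the same hydrogen-bond donor and acceptor counts, so those counts do not separate them. What differs is which halogen the ring carries, how many, and where, and no available evidence explains the loss of growth inhibition.

Because this swap changes all three features at once, the compounds shown cannot tell which of them matters. From the compounds shown here alone, it also remains open how a plain phenyl group, a pyridine ring or a methoxy-bearing phenyl group would behave on this carbon.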